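The source may hold more compounds than are shown below. What is called first, only, known or untested is meant among the compounds shown, and "the series" means these compounds.

Measured so far in a functional assay (trachea) with Rattus norvegicus as the target; a lower number here means a less potent compound, a higher number a more potent compound, by a factor of ten per unit of this negative logarithm:
compound 1, `COc1ccc(C(=O)c2ccc3c(c2)C(n2ccccc2=O)=CC(C)(C)O3)cc1`, gives 5.72
compound 2, `CC1(C)C=C(n2ccccc2=O)c2cc(C(=O)c3ccc([N+](=O)[O-])cc3)ccc2O1`, gives 6.09
compound 3, `CC1(C)C=C(n2ccccc2=O)c2cc(C(=O)c3ccccc3C(F)(F)F)ccc2O1`, gives 5.78

Compound 3 stands second highest of the three. Its nearest neighbour is compound 1, and the gap between them, a number 0.06 log units higher from compound 1 to compound 3 (within the scatter), lies within the scatter. Among the compounds with values here, compound 2 is the one number that stands apart, as a number 0.31 log units lower from compound 2 to compound 3 (beyond the scatter) shows; compound 2 also stands above compound 1 by a number 0.37 log units higher from compound 1 to compound 2 (beyond the scatter).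

Compound 4, `CC1(C)C=C(n2ccccc2=O)c2cc(C=O)ccc2O1`, has not yet been measured. Its change from compound 3 is hydrogen in place of 2-(trifluoromethyl)phenyl on a carbonyl carbon. Within the data shown here, no measured step removes the whole aryl group from the carbonyl carbon; the two steps that touch this position, a number 0.06 log units higher from compound 1 to compound 3 (within the scatter) and a number 0.31 log units lower from compound 2 to compound 3 (beyond the scatter), only exchange one aryl for another and stay modest in size. Taking the aryl away altogether is a larger change than anything measured, so a step beyond the scatter downward is expected, though the evidence for its size is thin. Compound 4 is estimated at 5.2, within 4.5 to 5.9, which means an expected step of a number 0.58 log units lower from compound 3 to compound 4 (beyond the scatter).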

Compound 4, logarithm of the reciprocal of the active concentration, log(1/C): 6.14
Compound 4: the middle estimate sits 0.94 log units below what was measured, outside the stated range (above it).
By their numbers in this assay, from the lowest: compounds 1 and 3 (each within the scatter of the next); then compounds 2 and 4 (each within the scatter of the next).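

In this assay the aryl group on the carbonyl carbon proves dispensable among these compounds: hydrogen in its place gives a higher number than two of the three aryl groups, both against 2-(trifluoromethyl)phenyl (a number 0.36 log units higher from compound 3 to compound 4 (beyond the scatter)) and against 4-methoxyphenyl (a number 0.42 log units higher from compound 1 to compound 4 (beyond the scatter)). Against 4-nitrophenyl the same exchange makes no real difference (a number 0.05 log units higher from compound 2 to compound 4 (within the scatter)), so none of the three aryl groups shown improves on hydrogen at this place. Nothing available accounts for this result.

The compounds shown leave open whether a methyl group, a hydroxyl group or an amine on the carbonyl carbon would hold this number. Also open, going by these compounds, is what a nitrile would give in place of the whole carbonyl group.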